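Swapping an Ethylamino Group for Acetyl on a Coumarin Core

The compounds below may be only part of what the source reports. "The series", "measured", "known", "first", "only" and "open" are said of these compounds alone.

For the measured compounds named here, compound 2 `CCNc1cc(=O)oc2cc(OCc3cccc(Cl)c3)ccc12` carries a small ethylamino group on the shared core, and in an assay on isolated protein (strain Sprague-Dawley) for inhibition of Amine oxidase [flavin-containing] B (Rattus norvegicus), read by spectrophotometry, with a stated time of 5 min (on this read-out higher numbers stand for weaker inhibition and lower numbers for stronger inhibition), compound 2 gives 28.2 nM, the lowest of the two numbers measured so far. Compound 1 `O=C(COc1cc(=O)oc2cc(OCc3cccc(Cl)c3)ccc12)N1CCCCC1` bears a much larger ((piperidin-1-yl)carbonyl)methoxy group at the same place, and in this assay compound 1 gives 38900 nM. Going by the values given here, the one measured step, a 1400-fold lower number from compound 1 to compound 2 (3.14 log units; beyond the scatter), shows that trimming that bulky group down to ethylamino makes inhibition far stronger.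

Compound 3 `CC(=O)c1cc(=O)oc2cc(OCc3cccc(Cl)c3)ccc12` differs from compound 2 by acetyl in place of ethylamino on an aromatic carbon. The change keeps the group about as small as in compound 2 but trades a hydrogen-bond donor for a carbonyl acceptor. Among the compounds with values here, the measured step only tells how strongly size matters; no measured pair tests swapping a donor for an acceptor at the same size, so that part is uncertain. Because small groups at this position fit well in compound 2 28.2 nM, compound 3 is expected to stay fairly potent, with a modest weakening a 3.5-fold higher number from compound 2 to compound 3 (0.55 log units; beyond the scatter). The estimate for compound 3 in this assay is 100 nM, ranging from 15 nM to 700 nM.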

Compound 3, half-maximal inhibitory concentration: 39.8 nM
For compound 3 the middle estimate is 2.5-fold (0.40 log units) above the measured one; measured number inside the range.
By their numbers in this assay, from the lowest: compounds 2 and 3 (each within the scatter of the next); then compound 1.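

In this assay, the change from ethylamino to acetyl gives a 1.4-fold higher number from compound 2 to compound 3 (0.15 log units; within the scatter), so in this pair the hydrogen-bond donor of ethylamino can go, leaving acetyl with 0 hydrogen-bond donors, without any change that can be told from the scatter. The large gap seen earlier also returns with the new group, as a 980-fold lower number from compound 1 to compound 3 (2.99 log units; beyond the scatter), which means the low number of compound 2 is not unique to ethylamino: two different groups of 3 heavy atoms both stand far from ((piperidin-1-yl)carbonyl)methoxy on the same aromatic carbon. No accompanying measurement explains why these two groups read alike.

The ((piperidin-1-yl)carbonyl)methoxy group differs from ethylamino and acetyl in several features at once, including its ring, its amide and its length, so the compounds shown do not reveal which of these features goes with the much higher number. Going by these compounds, it also remains open whether a plain primary amine, a carboxylic acid or a longer chain such as butylamino would read like compound 2 and compound 3 or move towards compound 1.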